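The source may report more compounds than this note shows. Statements on the series, on what has been measured and on what is new or still open speak of the compounds shown alone.

Measured compounds:
compound 1 `COc1cccc(OC)c1OCCNCCOc1ccccc1OCc1ccccc1Cl` – 5400 nM in a functional assay on PC-3 cells (Homo sapiens) for cytotoxicity, read by sulforhodamine B assay; on this read-out lower numbers stand for stronger inhibition of growth and higher numbers for weaker inhibition of growth
compound 2 `COc1cccc(OC)c1OCCNCCOc1ccccc1OCc1ccc([N+](=O)[O-])cc1` – 12000 nM in this assay

Going by the values given here, compound 2 stands at the higher of the two numbers in this assay; the only neighbour is compound 1, reached by a 2.2-fold higher number from compound 1 to compound 2 (0.35 log units; beyond the scatter), a step beyond the scatter in the direction of weaker growth inhibition.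

Compound 3 `COc1cccc(COc2ccccc2OCCNCCOc2c(OC)cccc2OC)c1` is not yet measured. It differs from compound 2 by 3-methoxyphenyl in place of 4-nitrophenyl on a saturated chain carbon bound to an oxygen on an aromatic ring. Among the compounds with values here, the one measured step at this position, a 2.2-fold higher number from compound 1 to compound 2 (0.35 log units; beyond the scatter), bears on it only indirectly: it exchanged a halogenated ring for a nitro-bearing ring, whereas here a methoxy-bearing ring enters, and no measured compound carries that group. Within the data shown here, the size of the change at this position so far has been modest, so a modest step in either direction, or none beyond the scatter, is expected in this assay.

Compound 3 is estimated at 8000 nM, with a range of 3000 nM to 20000 nM, which means an expected step of a 1.5-fold lower number from compound 2 to compound 3 (0.18 log units; within the scatter).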

Compound 3, concentration for 50% growth inhibition: 2500 nM
Compound 3: the middle estimate sits 3.2-fold (0.51 log units) above what was measured, outside the stated range (below it).
By their numbers in this assay, from the lowest: compound 3; then compound 1; then compound 2.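

In this assay this position now moves the number in both directions, since 3-methoxyphenyl in place of 4-nitrophenyl gives a 4.8-fold lower number from compound 2 to compound 3 (0.68 log units; beyond the scatter) and 3-methoxyphenyl in place of 2-chlorophenyl gives a 2.2-fold lower number from compound 1 to compound 3 (0.33 log units; beyond the scatter) on the same core. Compound 3 therefore holds the lowest number of the three, with both steps beyond the scatter, and the order of the groups is 3-methoxyphenyl, then 2-chlorophenyl, then 4-nitrophenyl. No measurement at hand accounts for this order.

Still open, as far as these compounds go, is how an unsubstituted phenyl ring, or an amine or a carboxylic acid on this ring, would stand against 3-methoxyphenyl, and whether the methoxy group itself or its place on the ring carries the difference. Also open, from the compounds shown here alone, is whether this order of the three groups holds on any other core.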